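The source may hold more compounds than are shown below. What is called first, only, known or untested is meant among the compounds shown, and "the series" means these compounds.

Of the compounds shown here, three that share one core have been measured in a functional assay on HCT-15 cells (Homo sapiens) for inhibition; a higher number here means a weaker inhibitor, a lower number a stronger inhibitor. Compound 1 `Oc1ccc(-c2cc(-c3ccccc3F)cc(-c3cccc(O)c3)n2)cc1` gives 5630 nM in this assay. Compound 2 `Oc1ccc(-c2cc(-c3ccccc3F)cc(-c3ccc(O)cc3)n2)cc1` gives 8180 nM, and compound 3 `Oc1ccc(-c2cc(-c3cccc(C(F)(F)F)c3)cc(-c3cccc(O)c3)n2)cc1` gives 9540 nM. Among these three numbers compound 2 stands second highest; its value and that of compound 3 lie close together, and the step of a 1.5-fold higher number from compound 1 to compound 2 (0.16 log units; within the scatter) is within the scatter, so no ordering among the three can be claimed.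

The step from compound 2 to compound 4 `Oc1ccc(-c2cc(-c3ccc(C(F)(F)F)cc3)cc(-c3ccc(O)cc3)n2)cc1` makes one change: 4-(trifluoromethyl)phenyl in place of 2-fluorophenyl on an aromatic carbon. The closest measured precedent is a 1.7-fold higher number from compound 1 to compound 3 (0.23 log units; within the scatter), where a 2-fluorophenyl group likewise gave way to a phenyl group carrying trifluoromethyl, and that step stayed within the scatter. Nothing measured here points to a movement beyond the scatter.

Compound 4 is therefore expected to give about 10500 nM in this assay, with a likely range from 5000 nM to 22000 nM. That estimate means a step of a 1.3-fold higher number from compound 2 to compound 4 (0.11 log units; within the scatter), expected to stay within the scatter or only just beyond it.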

Compound 4, half-maximal inhibitory concentration: > 50000 nM
Compound 4: only a limit was reported; the forecaster's own chance of this, stated with the estimate: 10%; middle value at least 4.7-fold (0.67 log units) away from the limit.
By their numbers in this assay, from the lowest: compounds 1, 2 and 3 (each within the scatter of the next). At a limit, above all of these: compound 4.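

For compound 4, this assay reports > 50000 nM as a limit of the assay, not a number. Among the compounds shown here, replacing 2-fluorophenyl with 4-(trifluoromethyl)phenyl on this carbon, opposite the ring nitrogen, gives an at least 6.1-fold higher number from compound 2 to compound 4 (0.78 log units; beyond the scatter) and so moves beyond the scatter, which no earlier step did. This carbon is therefore sensitive to which group it carries, whereas the earlier change gave a 1.7-fold higher number from compound 1 to compound 3 (0.23 log units; within the scatter) and stayed within the scatter, and the result rests on a limit rather than on a number: the limit of > 50000 nM in this assay, at which 1 of the 4 values shown sits.

Compound 3 and compound 4 differ in two places, so the compounds shown cannot separate the place of the trifluoromethyl group from the change of hydroxyphenyl group. Also open, on these data alone, is how a phenyl group carrying an amine or a carboxylic acid would behave on this carbon.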